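Swapping 2-methoxyphenyl for 3-methylphenyl: an expected limit

The source may report more compounds than this note shows. Statements on the series, on what has been measured and on what is new or still open speak of the compounds shown alone.

Compound 1 `COc1ccccc1Nc1nc(-c2cccc(F)c2)nc2ccc(F)cc12` was tested in a functional assay on U-937 cells (Homo sapiens) for cytotoxicity, read by MTT assay, with a stated time of 48 h; on this read-out higher numbers stand for weaker inhibition and lower numbers for stronger inhibition. In that test compound 1 reaches only a limit of the assay, > 50000 nM, so no actual number is known for it. Compound 2 `Oc1cccc(Nc2nc(-c3cccc(F)c3)nc3ccc(F)cc23)c1` likewise stops at a limit, > 50000 nM. Among the compounds with values here, the one measured step, a step that the two limits leave unreadable from compound 1 to compound 2, therefore cannot be read. Compound 3 `Cc1cccc(Nc2nc(-c3cccc(F)c3)nc3ccc(F)cc23)c1` differs from compound 1 by 3-methylphenyl in place of 2-methoxyphenyl on a nitrogen on an aromatic ring. Both measured values sit at the limit of > 50000 nM in this assay, at which 2 of the 2 values shown sit, so no step size can be drawn from them, and compound 3 is expected to stay near that limit as well, a step that the limit leaves unreadable from compound 1 to compound 3. Compound 3 is estimated at 60000 nM, within 20000 nM to 150000 nM.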

Compound 3, half-maximal inhibitory concentration: > 50000 nM
Compound 3 gave a limit, no number; the forecaster's own chance of this, stated with the estimate: 75%; the middle value lies beyond the limit too.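

Within the data shown here, compound 1, compound 2 and compound 3 all stop at a limit of the assay, so no step between them can be read: the limit of > 50000 nM in this assay, at which 3 of the 3 values shown sit. As far as these compounds go, how far each compound lies beyond that limit remains open, as does whether swapping these groups changes the result at all.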